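This account rests on a few compounds, and the source may have more. Where it says the series, first, only, none or still open, it means among the compounds named here.

Measured in a functional assay on MGC-803 cells (Homo sapiens) for inhibition, read by MTT assay, with a stated time of 72 h; a lower number here means a stronger inhibitor, a higher number a weaker inhibitor:
- compound 1 `Cc1ccc(NC(=O)C2CCN(C/C=C/c3ccccc3)CC2)cc1`: 24100 nM
- compound 2 `O=C(Nc1cccc(Br)c1)C1CCN(C/C=C/c2ccccc2)CC1`: 9110 nM
- compound 3 `O=C(Nc1ccccn1)C1CCN(C/C=C/c2ccccc2)CC1`: 45200 nM

Compound 3 stands at the weak end of this small set, together with compound 1. Compound 4 `O=C(NCc1ccccc1)C1CCN(C/C=C/c2ccccc2)CC1` is not yet measured. It has benzyl in place of pyridin-2-yl on an amide-type nitrogen. The closest guides are the two steps that put pyridin-2-yl on this nitrogen, a 1.9-fold higher number from compound 1 to compound 3 (0.27 log units; within the scatter) and a 5.0-fold higher number from compound 2 to compound 3 (0.70 log units; beyond the scatter). Neither involves benzyl, so they guide only loosely. The expected change is small and toward a lower number, a 1.8-fold lower number from compound 3 to compound 4 (0.26 log units; within the scatter). For compound 4 the estimate is 25000 nM, with an expected range of 9000 nM to 60000 nM.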

Compound 4, half-maximal inhibitory concentration: > 100000 nM
Compound 4: a limit, no number; the forecaster's own chance of this, stated with the estimate: 10%; middle value at least 4.0-fold (0.60 log units) from the limit.
By their numbers in this assay, from the lowest: compound 2; then compounds 1 and 3 (each within the scatter of the next). At a limit, above all of these: compound 4.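

In this assay, compound 4 gives a limit, not a number: the limit of > 100000 nM in this assay, at which 1 of the 4 values shown sits. Each step to it lies beyond the scatter: an at least 2.2-fold higher number from compound 3 to compound 4 (0.34 log units; beyond the scatter), an at least 4.1-fold higher number from compound 1 to compound 4 (0.61 log units; beyond the scatter) and an at least 10-fold higher number from compound 2 to compound 4 (1.04 log units; beyond the scatter). The earlier groups on this amide-type nitrogen gave at most modest steps, so benzyl shows that a change here can cost much more.

On these data alone, the true size of these steps stays unknown, as compound 4 has only a limit. Also open, as far as these compounds go, is how a longer chain such as 2-phenylethyl, or a benzyl ring carrying bromine, would behave at this nitrogen.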